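This account rests on a few compounds, and the source may have more. Where it says the series, first, only, none or still open, it means among the compounds named here.

Of the compounds shown here, two of a shared core have so far been measured in a functional assay on SW480 cells (Homo sapiens) for antiproliferative activity, read by MTT assay, with a stated time of 48 h; on this read-out lower numbers stand for stronger inhibition and higher numbers for weaker inhibition. Compound 1 `O=c1cc(-n2cc(CNc3ccccc3)nn2)c2cc(Br)ccc2o1` carries an anilino group on the chain that leaves the triazole, and in this assay compound 1 gives 18400 nM. Compound 2 `O=c1cc(-n2cc(COc3ccccc3O)nn2)c2cc(Br)ccc2o1` carries a 2-hydroxyphenoxy group in the same place, and in this assay compound 2 gives 19100 nM. Among the measured compounds shown here, the one step measured so far is a 1.0-fold higher number from compound 1 to compound 2 (0.02 log units; within the scatter). On the two numbers shown, compound 2 has the higher one, yet its gap to compound 1 is within the scatter, so no order between them can be read.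

Compound 3 `O=c1cc(-n2cc(COc3ccc(Br)cc3)nn2)c2cc(Br)ccc2o1` is not yet measured. It differs from compound 2 in one place: 4-bromophenyl in place of 2-hydroxyphenyl on an oxygen on a saturated carbon. For the measured compounds named here, the only step that bears on this change is the swap at the same outer position from compound 1 to compound 2, which stayed within the scatter. On that basis, the change from compound 2 to compound 3 is expected to bring no step beyond the scatter, that is, an expected 1.1-fold lower number from compound 2 to compound 3 (0.03 log units; within the scatter). In this assay compound 3 is therefore estimated at 18000 nM, within a range from 7000 nM to 45000 nM.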

Compound 3, half-maximal inhibitory concentration: 1310 nM
Compound 3: the middle estimate sits 14-fold (1.14 log units) above what was measured; the measured number lies below the stated range.
By their numbers in this assay, from the lowest: compound 3; then compounds 1 and 2 (each within the scatter of the next).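

In this assay, among the compounds shown here, the group on the oxygen on a saturated carbon proves able to move the number strongly: 4-bromophenyl in place of 2-hydroxyphenyl gives a 15-fold lower number from compound 2 to compound 3 (1.16 log units; beyond the scatter), whereas the only earlier swap at this outer end stayed within the scatter. The comparison with the anilino compound points the same way, with 4-bromophenoxy in place of anilino giving a 14-fold lower number from compound 1 to compound 3 (1.15 log units; beyond the scatter), so the likeness of compound 1 and compound 2 did not mean that this end of the molecule is insensitive to change. No measurement is available to explain why this change lowers the number so much.

The change removes the hydroxyl group and adds the bromine in a single step, and it also moves the substituent to a different place on the ring, so the compounds shown leave open which of these differences carries the step. A plain phenyl on the same oxygen, or a chlorine or a methoxy group in place of the bromine, would help to separate these differences and show how specific the gain is to bromine.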